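The compounds below may be only part of what the source reports. "The series", "measured", "known", "first", "only" and "open" are said of these compounds alone.

Measured in a functional assay on HeLa cells (Homo sapiens) for inhibition, read by CCK-8 assay, with a stated time of 48 h; on this read-out higher numbers stand for weaker inhibition and lower numbers for stronger inhibition:
- compound 1 `COc1ccc(NC(=O)NCCNS(=O)(=O)c2ccc(-c3ccccc3OCc3ccccc3)s2)cc1`: > 50000 nM (a limit)
- compound 2 `Cc1cc(C)cc(NC(=O)NCCNS(=O)(=O)c2ccc(-c3ccccc3Oc3ccc([N+](=O)[O-])c([N+](=O)[O-])c3)s2)c1`: 12000 nM
- compound 3 `COc1cccc(NC(=S)NCCNS(=O)(=O)c2ccc(-c3ccccc3Oc3ccc([N+](=O)[O-])cc3)s2)c1`: > 50000 nM (a limit)

Compound 3 has no number, only the limit > 50000 nM. It therefore sits with the limit of > 50000 nM in this assay, at which 2 of the 3 values shown sit, and any step away from it can only be sized loosely. Among the measured compounds shown here, compound 2 is the only member with a true number, at 12000 nM.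

Compound 4 `COc1ccc(NC(=O)NCCNS(=O)(=O)c2ccc(-c3ccccc3Oc3ccc([N+](=O)[O-])cc3)s2)cc1` is the next member to be read in this assay. It keeps the core of compound 3 and carries (4-methoxyphenyl)carbamoyl on the amine nitrogen: a group of 11 heavy atoms (8 carbon, 1 nitrogen, 2 oxygen; one six-membered aromatic ring of carbon only) in place of a group of 11 heavy atoms (8 carbon, 1 nitrogen, 1 oxygen, 1 sulfur; one six-membered aromatic ring of carbon only), on an amine nitrogen.

For the measured compounds named here, no measured step isolates this change, so the expectation rests on the values alone. Compound 1 also gives only a limit, > 50000 nM. This makes a result at the limit a real possibility for compound 4. Compound 2, at 12000 nM, shows that a measurable value can be reached in this set, so a modest move toward stronger inhibition is expected rather than a large one.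

The expected size of the change is an at least 1.6-fold lower number from compound 3 to compound 4 (0.22 log units; that floor lies within the scatter), and this remains a rough estimate. For compound 4 the estimated value is 30000 nM, with an expected range of 9000 nM to 50000 nM.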

Compound 4, half-maximal inhibitory concentration: > 20000 nM
Compound 4 gave a limit, no number; the forecaster's own chance of this, stated with the estimate: 45%; the middle value does not contradict the limit.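

In this assay compound 4 gives only a limit, > 20000 nM. Compound 3 and compound 1 also give only limits, and neither step to compound 4 can be read. The compounds shown leave open whether (4-methoxyphenyl)carbamoyl on the amine nitrogen, or 4-nitrophenyl in place of benzyl, changes inhibition at all.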